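The source may report more compounds than this note shows. Statements on the series, on what has been measured and on what is new or still open speak of the compounds shown alone.

Compound 1 `O=C(Nc1ncccc1N1CCN(C(=O)Cn2cnc3cccnc32)CC1)c1cccc(Cl)c1` gives 177 nM in a functional assay on CHO-K1 cells for antagonist activity at C-X-C chemokine receptor type 3 (Homo sapiens), read by FLIPR, with a stated time of 10 min; a lower number here means a stronger inhibitor, a higher number a weaker inhibitor.
Compound 2 `O=C(Cn1cnc2cccnc21)N1CCN(c2ncsc2-c2nc3ccccc3[nH]2)CC1` gives 4210 nM in this assay.
Compound 3 `Cc1nc(-c2nc3ccccc3[nH]2)c(N2CCN(C(=O)Cn3cnc4cccnc43)[C@H](C)C2)s1` gives 9 nM in this assay.

Of these three, compound 3 stands at the lowest number, which in this assay means the strongest inhibitor of the set. Its nearest neighbour is compound 1, whose number lies well above, a gap beyond the usual scatter of repeated measurements; compound 2 lies further still, also beyond the scatter. Compound 3 is therefore clearly set apart from both.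

Compound 4 `C[C@@H]1CN(c2sc(CN(C)C)nc2-c2nc3ccccc3[nH]2)CCN1C(=O)Cn1cnc2cccnc21` is built from compound 3 by one change: dimethylamino in place of hydrogen on a saturated chain carbon bound to an aromatic carbon. No measured pair in this set carries this change, so nothing shown here tells directly how it will play out. The group that enters is small and sits on a saturated chain carbon at the edge of the shared core, away from the part where compounds 1, 2 and 3 differ most from one another. On that basis the step from compound 3 to compound 4 is expected to be modest, leaning toward a somewhat higher number, but it could also stay within the scatter; the expected step is a 2.2-fold higher number from compound 3 to compound 4 (0.35 log units; beyond the scatter). Compound 4 is estimated to give 20 nM in this assay, with a plausible range from 5 nM to 80 nM.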

Compound 4, half-maximal inhibitory concentration: 50 nM
Compound 4: the middle estimate sits 2.5-fold (0.40 log units) below what was measured; the measured number falls inside the stated range.
By their numbers in this assay, from the lowest: compound 3; then compound 4; then compound 1; then compound 2.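

In this assay, among these compounds, putting dimethylamino in place of hydrogen on a saturated chain carbon bound to an aromatic carbon gives a 5.6-fold higher number from compound 3 to compound 4 (0.74 log units; beyond the scatter), so this change has a real cost, and the first direct reading at this place shows that the number moves with what is attached there. The cost is limited, though: with the larger (dimethylamino)methyl group in place of methyl, compound 4 still gives 50 nM, so this place accepts an added group of 3 heavy atoms without losing activity altogether. Nothing measured here accounts for the rise in the number, so the step records an outcome and not its cause.

A single step cannot show whether the rise goes with the nitrogen of the dimethylamino group or with the added atoms alone, and a methoxy group or a plain ethyl chain at this place, neither of which contains nitrogen, would help separate the two. Also open, on these data alone, is how a ring amine such as morpholine, or a longer chain carrying the same dimethylamino group, would read in this assay.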